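A few compounds are considered here, and "the series" means these few. Any claim that something is new, unique, unknown or untested is made for them only; others in the source may bear on it.

Compound 1 `c1ccc(-c2ccc(Cn3cncc3CNc3ccc(-c4onc5ccccc45)c(-c4ccccc4)c3)cc2)cc1` — > 10000 nM
Compound 2 `COC(=O)c1ccc(NCc2cncn2Cc2cccc(C#N)c2)cc1-c1ccccc1` — > 10000 nM

Both values come from a toxicity assay on NIH3T3 cells (Mus musculus) for cytotoxicity, read by resazurin assay; on this read-out lower numbers stand for an effect already at smaller amounts and higher numbers for an effect only at larger amounts of compound. In this assay compound 2 gives > 10000 nM, which is a limit of the assay rather than a measured number. Compound 1 likewise gives only a limit, > 10000 nM. So compound 2 stands exactly where every value shown stands: the limit of > 10000 nM in this assay, at which 2 of the 2 values shown sit. Nothing in these two values separates the compounds from each other.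

Compound 3 `COC(=O)c1ccc(NCc2cncn2Cc2ccc(-c3ccccc3)cc2)cc1-c1ccccc1` has not yet been tested. It differs from compound 2 in one place: 4-phenylphenyl in place of 3-cyanophenyl on a saturated chain carbon bound to an aromatic nitrogen. For the measured compounds named here, no measured pair of compounds shows what this change does in this assay. With both measured compounds sitting at the limit, the step that the limit leaves unreadable from compound 2 to compound 3 is expected to be none beyond the usual scatter, in no particular direction. Compound 3 is therefore estimated at 20000 nM, within 8000 nM to 60000 nM, and most likely reported again only as a limit.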

Compound 3, half-maximal effective concentration: > 1000 nM
Compound 3 ended at the assay's limit; the forecaster's own chance of this, stated with the estimate: 80%; the middle value lies beyond the limit too.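

For the compounds shown here, compound 3 gives only a limit in this assay, as do compound 1 and compound 2, so no step from compound 1 or compound 2 to compound 3 can be read. The compounds shown leave open at what concentration any of the three would harm these cells.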